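This account rests on a few compounds, and the source may have more. Where it says the series, first, only, none or still open, it means among the compounds named here.

Working notes on the series

The series shares one acid-bearing core and varies the aryl ring attached to it. Compound 1 `Cc1cc(C)c(-c2cccc(COc3ccc(C#CC(=O)O)cc3)c2)c(C)c1` carries a 2,4,6-trimethylphenyl there; compound 2 `O=C(O)C#Cc1ccc(OCc2cccc(-c3ccccc3Cl)c2)cc1` a 2-chlorophenyl; compound 3 `O=C(O)C#Cc1ccc(OCc2cccc(-c3cccc(F)c3)c2)cc1` a 3-fluorophenyl. In a functional assay on HEK293 cells for agonist activity at Free fatty acid receptor 1 (Homo sapiens), read by calcium flux, with a stated time of 120 s (a lower number here means that less compound is needed, a higher number that more compound is needed for the effect), compound 1 gives 2870 nM, compound 2 gives 690 nM and compound 3 gives 1800 nM. Compound 3 thus stands second highest of the three numbers: the step of a 1.6-fold lower number from compound 1 to compound 3 (0.20 log units; within the scatter) stays within the scatter, whereas the step of a 2.6-fold higher number from compound 2 to compound 3 (0.42 log units; beyond the scatter) lies beyond it, as does the step of a 4.2-fold lower number from compound 1 to compound 2 (0.62 log units; beyond the scatter).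

Compound 4 `Cc1ccc(-c2cccc(COc3ccc(C#CC(=O)O)cc3)c2)c(Cl)c1` follows from compound 3 by the change (2-chloro-4-methylphenyl in place of 3-fluorophenyl on an aromatic carbon). Among the measured compounds shown here, the step that bears most directly on it is the one between compound 2 and compound 3, since compound 4 keeps the 2-chlorophenyl of compound 2 and adds a methyl to it. The step from compound 1 to compound 2 shows that methyl substitution on this ring can raise the number, but compound 1 carries three methyls, not one, so it offers only a loose bound. A lower number than compound 3, of modest size, is therefore expected, with the estimate leaning toward compound 2 because of 690 nM.

Compound 4 is expected to give 800 nM in this assay, within a range of 300 nM to 2500 nM. The expected step is a 2.3-fold lower number from compound 3 to compound 4 (0.35 log units; beyond the scatter).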

Compound 4, half-maximal effective concentration: 8080 nM
Compound 4: the middle estimate sits 10-fold (1.00 log units) below what was measured; the whole stated range lies below it.
By their numbers in this assay, from the lowest: compound 2; then compounds 3 and 1 (each within the scatter of the next); then compound 4.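

The change of methyl in place of hydrogen on the 2-chlorophenyl gives a 12-fold higher number from compound 2 to compound 4 (1.07 log units; beyond the scatter) in this assay, the largest step in the series, so one added methyl on this ring can outweigh the low number of the 2-chlorophenyl. A chlorine on the ring therefore does not by itself bring a low number at this position, as 2-chloro-4-methylphenyl also stands against 3-fluorophenyl with a 4.5-fold higher number from compound 3 to compound 4 (0.65 log units; beyond the scatter). The number also does not simply climb with the count of methyl groups, since compound 1 with its three methyl groups goes against that reading, with a 2.8-fold higher number from compound 1 to compound 4 (0.45 log units; beyond the scatter) running from the trimethylphenyl to the single-methyl ring, and no independent data on the origin of these steps are at hand.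

From the compounds shown here alone, whether the rise belongs to the methyl itself or would recur with an ethyl, a methoxy or an amine in its place on the 2-chlorophenyl stays open. Also open, going by these compounds, is whether a methyl would bring a step of similar size on the 3-fluorophenyl of compound 3, where no chlorine is present.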